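The source may hold more compounds than are shown below. What is called first, only, known or untested is meant among the compounds shown, and "the series" means these compounds.

Working notes on the series. Among the measured compounds shown here, in a functional assay on NCI-H460 cells (Homo sapiens) for inhibition, read by sulforhodamine B assay, with a stated time of 48 h (on this read-out higher numbers stand for weaker inhibition of growth and lower numbers for stronger inhibition of growth), compound 3 (`CC(C)(C)NCc1c(C(=O)O)nn(-c2ccccc2)c1-c1ccc(Cl)cc1`) gives 70500 nM as the only single number so far. Compound 1 (`CCOC(=O)c1nn(-c2ccccc2)c(-c2ccccc2)c1CNC(C)(C)C`) has two entries (76900 nM; 195000 nM (2 entries)). Compound 2 (`CC(C)(C)NCc1c(C(=O)O)nn(-c2ccccc2)c1-c1ccc(F)cc1`) gives only a limit (> 680000 nM). Compound 4 (`CC(C)(C)NCc1c(C(=O)O)nn(-c2ccccc2)c1-c1ccccc1`) is still unmeasured and differs from compound 3 by hydrogen in place of chloro on an aromatic carbon as hydrogen in place of chloro on an aromatic carbon. Because of an at least 9.6-fold lower number from compound 2 to compound 3 (0.98 log units; beyond the scatter) a moderate step to a higher number is expected in this assay when the chloro leaves, though that measured step rests on a limit. The expected change is a 2.8-fold higher number from compound 3 to compound 4 (0.45 log units; beyond the scatter) and stays an estimate. For compound 4 the estimated value is 200000 nM (expected range 70000 nM to 600000 nM).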

Compound 4, concentration for 50% growth inhibition: > 716000 nM
Compound 4: only a limit was reported (the forecaster's own chance of this, stated with the estimate: 25%); middle value at least 3.5-fold (0.55 log units) away from the limit.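

With hydrogen in place of chloro on the aromatic carbon, the result is an at least 10-fold higher number from compound 3 to compound 4 (1.00 log units; beyond the scatter), so the earlier gain from fluoro to chloro now has a second reference point: the phenyl compound as well as the 4-fluorophenyl compound lies on the weak side of compound 3. Compound 4 gives only a limit, as does compound 2, so the step between them cannot be read and no order of hydrogen and fluoro follows. Open, as far as these compounds go, is whether a bromo or a methoxy group at this place matches chloro, and whether chloro has a similar effect on the ethyl ester, compound 1.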